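Allyloxy to methyl on the carbonyl: working notes

The source may report more compounds than this note shows. Statements on the series, on what has been measured and on what is new or still open speak of the compounds shown alone.

Measured in a functional assay on PC-3 cells (Homo sapiens) for inhibition, read by MTT assay, with a stated time of 96 h; a lower number here means a stronger inhibitor of growth, a higher number a weaker inhibitor of growth
- compound 1 `C=CCOC(=O)SCCCCCCNC(=O)c1cc(-c2ccncc2)n[nH]1` gives 24800 nM
- compound 2 `CCCCCCCC/C=C\CCCCCCCC(=O)SCCCCCCNC(=O)c1cc(-c2ccncc2)n[nH]1` gives > 50000 nM as a limit of the assay

In this assay, within the data shown here, compound 1 at 24800 nM holds the only number so far. The result for compound 2 is a limit. Compound 3 `CC(=O)SCCCCCCNC(=O)c1cc(-c2ccncc2)n[nH]1` has methyl in place of allyloxy on a carbonyl carbon and awaits measurement. Among the measured compounds shown here, no measured step calibrates this change, so only a modest gain in growth inhibition is expected. The estimated step of a 2.5-fold lower number from compound 1 to compound 3 (0.39 log units; beyond the scatter) lies little beyond the scatter. For compound 3 the expected value is 10000 nM, with an estimated range from 2500 nM to 40000 nM.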

Compound 3, concentration for 50% growth inhibition: 36000 nM
Estimate against measurement, compound 3: 3.6-fold (0.56 log units) below; measured number inside the range.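

In this assay, methyl in place of allyloxy on a carbonyl carbon gives a 1.5-fold higher number from compound 1 to compound 3 (0.16 log units; within the scatter). Compound 1 and compound 3 therefore cannot be told apart at this position, although the two groups differ in size and only allyloxy carries a double bond. Nothing available accounts for this step.

For compound 2 the result is a limit of the assay, > 50000 nM, not a number. From the compounds shown here alone, whether an amine or a phenyl group on this carbonyl carbon would separate from compound 1 and compound 3 remains open.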